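Cyano in Place of Chloro on the Amide Aryl Group

This account rests on a few compounds, and the source may have more. Where it says the series, first, only, none or still open, it means among the compounds named here.

Measured compounds:
compound 1 `O=C(C1CCCCO1)N1CCc2nc(C#Cc3ccccc3)sc2C1`, an assay on HEK293 cells for negative allosteric modulation of metabotropic glutamate receptor 5 (Homo sapiens), read by FLIPR, with a stated time of 1 h; a lower number here means a stronger inhibitor, a higher number a weaker inhibitor: > 10000 nM
compound 2 `O=C(c1cccc(Cl)c1)N1CCc2nc(C#Cc3ccccc3)sc2C1`, this assay: > 10000 nM

Compound 1 carries an oxan-2-yl group on the carbonyl carbon, while compound 2 carries 3-chlorophenyl in its place. In this assay compound 1 gives only a limit of the assay, > 10000 nM. In this assay compound 2 likewise gives only a limit, > 10000 nM. The step that the two limits leave unreadable from compound 1 to compound 2 therefore cannot be read, and the limit of > 10000 nM in this assay, at which 2 of the 2 values shown sit, is all the evidence the two measured compounds offer. Compound 2 thus stands at the limit, with no number of its own.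

Compound 3 `N#Cc1cccc(C(=O)N2CCc3nc(C#Cc4ccccc4)sc3C2)c1` differs from compound 2 in one place: cyano in place of chloro on an aromatic carbon. Among the compounds with values here, no measured step bears on this change, since the one step available is unreadable. With compound 2 at its limit > 10000 nM, the expectation for compound 3 in this assay is that it again falls at or beyond the limit rather than giving a readable number. The estimated step that the limit leaves unreadable from compound 2 to compound 3 is therefore expected to be none beyond the scatter. Compound 3 is estimated at 12000 nM, within the range 3000 nM to 40000 nM.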

Compound 3, half-maximal inhibitory concentration: > 10000 nM
Compound 3 ended at the assay's limit; the forecaster's own chance of this, stated with the estimate: 70%; the middle value is on the limit's open side.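

In this assay compound 3 gives > 10000 nM as a limit of the assay and not a number. Like compound 1 and compound 2, it has no number of its own, so no step from either of them to compound 3 can be read. The compounds shown leave open how strongly any of the three inhibits the receptor, and whether 3-cyanophenyl and 3-chlorophenyl differ at all.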